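Methyl for methylsulfonyl on the fused core: stability outlook

The compounds below may be only part of what the source reports. "The series", "measured", "known", "first", "only" and "open" are said of these compounds alone.

Measured so far:
- compound 1 `COc1nn2cc(-c3cc4ccccc4o3)nc2s1`: 31%
- compound 2 `CS(=O)(=O)c1nn2cc(-c3cc4ccccc4o3)nc2s1`: "not determined" (no result reported)
- compound 3 `COc1cc(OCc2cccc(O)c2)c2cc(-c3cn4nc(OC)sc4n3)oc2c1`: 49%

In an ADME assay on microsomes from liver (Rattus norvegicus) for metabolic stability, with a stated time of 10 min (on this read-out lower numbers stand for a less stable compound and higher numbers for a more stable compound), compound 1 gives 31% and compound 3 gives 49%. Going by the values given here, for compound 2 `CS(=O)(=O)c1nn2cc(-c3cc4ccccc4o3)nc2s1` the entry in this assay reads "not determined" (no result reported), so it stands nowhere on this read-out and no step from it can be counted. Compound 4 `Cc1nn2cc(-c3cc4ccccc4o3)nc2s1` differs from compound 2 in one place: methyl in place of methylsulfonyl on an aromatic carbon. Among the compounds with values here, with no measured step available, the expected size of the change in this assay is unknown; any direction is possible, and the value of compound 1, which carries a different single-carbon group at the same place, is the closest point of reference. Compound 4 is therefore expected to give about 35% in this assay, in the range 15% to 60%.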

Compound 4, percent of the compound remaining: 4%
Beside the measured number, compound 4's estimate is 31 percentage points above it; measured number outside the range, below it.
By their numbers in this assay, from the lowest: compound 4; then compound 1; then compound 3.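

Going by these compounds alone, at this carbon of the shared core, methyl in place of methoxy gives a number 27 percentage points lower from compound 1 to compound 4 (beyond the scatter) in this assay, the first single-place step. The read-out therefore responds to an exchange of one small group at this position, and methoxy is the better of the two groups compared here. Nothing at hand explains this step.

The step from compound 2 cannot be read. Open, as far as these compounds go, are how an amine or a longer chain at this carbon would read in this assay, and whether the same exchange on compound 3 would give a step of similar size.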